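Difluorophenyl ketone in the chalcone pyrazole series

The source may report more compounds than this note shows. Statements on the series, on what has been measured and on what is new or still open speak of the compounds shown alone.

Measured so far in a functional assay on HCC 2998 cells (Homo sapiens) for inhibition, read by sulforhodamine B assay, with a stated time of 48 h; a higher number here means that more compound is tolerated, a lower number that less compound is tolerated:
compound 1 `COc1cc(-c2cc(/C=C/C(=O)c3ccc(Cl)c(Cl)c3)[nH]n2)cc(OC)c1OC`: > 100000 nM
compound 2 `COc1ccc(C(=O)/C=C/c2cc(-c3cc(OC)c(OC)c(OC)c3)n[nH]2)cc1OC`: 6700 nM

The value given for compound 1 is a limit of the assay, not a number (the limit of > 100000 nM in this assay, at which 1 of the 2 values shown sits). Among the measured compounds shown here, compound 2 is the only compound with a number in this assay; the other value shown is a limit. For the measured compounds named here, the one measured step, an at least 14-fold lower number from compound 1 to compound 2 (1.17 log units; beyond the scatter), came with 3,4-dimethoxyphenyl in place of 3,4-dichlorophenyl on the carbonyl carbon.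

Compound 3 `COc1cc(-c2cc(/C=C/C(=O)c3ccc(F)c(F)c3)[nH]n2)cc(OC)c1OC` has not been measured. It differs from compound 2 as follows: 3,4-difluorophenyl in place of 3,4-dimethoxyphenyl on a carbonyl carbon. This change moves back toward the kind of group present in compound 1, so the step from compound 1 to compound 2 is the one that bears on it, and it was large. A higher number is therefore expected for compound 3, and the estimated step is a 7.5-fold higher number from compound 2 to compound 3 (0.87 log units; beyond the scatter). For compound 3 the expected value is 50000 nM, with a range from 12000 nM to 200000 nM; a limit rather than a number would not be surprising.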

Compound 3, concentration lethal to 50% of the cells: > 100000 nM
Compound 3: only a limit was reported; the forecaster's own chance of this, stated with the estimate: 45%; at least 2.0-fold (0.30 log units) between middle value and limit.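

In this assay compound 3 gives > 100000 nM, a limit of the assay and not a number. The change on the carbonyl carbon comes with an at least 14-fold higher number from compound 2 to compound 3 (1.17 log units; beyond the scatter), so the drop to a limit is no longer tied to 3,4-dichlorophenyl alone: among the three compounds shown, 3,4-dimethoxyphenyl stands against two dihalophenyl groups, and only compound 2 gives a number. The step between compound 1 and compound 3 cannot be read, so the two dihalophenyl groups cannot be ordered, and the comparison ends at the top of the range: the limit of > 100000 nM in this assay, at which 2 of the 3 values shown sit.

Open, on these data alone, is whether a 3,4-dihydroxyphenyl group, a single methoxy group or an amine on the phenyl ring would also give a number in this assay. Also open, as far as these compounds go, is how far compound 1 and compound 3 lie beyond the limit.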